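Piperidine to pyrrolidine exchange on a glutaramide series

This account rests on a few compounds, and the source may have more. Where it says the series, first, only, none or still open, it means among the compounds named here.

Four compounds share a glutaramide backbone carrying an aminoindane amide on one end and a basic amine chain on the other. Compound 1 `O=C(CC(CC(=O)NC1Cc2ccccc2C1)c1ccccc1)NCCN1CCCCC1` and compound 2 `O=C(CC(CC(=O)NC1Cc2ccccc2C1)c1ccccc1)NCCN1CCCC1` carry an unsubstituted phenyl and a secondary amide to the indane; compound 3 `CCN(C(=O)CC(CC(=O)NCCN1CCCCC1)c1ccc(Cl)cc1)C1Cc2ccccc2C1` and compound 4 `CCN(C(=O)CC(CC(=O)NCCN1CCCC1)c1ccc(Cl)cc1)C1Cc2ccccc2C1` carry a chlorophenyl and an ethyl group on that amide nitrogen. How the core of compound 3 differs from the core of compound 1 is not broken down here.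

In a functional assay on MCF7 cells (Homo sapiens) for inhibition (a higher number here means a weaker inhibitor, a lower number a stronger inhibitor), compound 1 gives > 100000 nM, which is a limit of the assay. Compound 2 likewise gives > 100000 nM in this assay, again a limit. Both sit at the limit of > 100000 nM in this assay, at which 2 of the 3 values shown sit, so the change pyrrolidin-1-yl in place of piperidin-1-yl on a saturated chain carbon, two bonds along the chain from an amide-type nitrogen yields a step that the two limits leave unreadable from compound 1 to compound 2. Among the compounds with values here, compound 3 gives 16500 nM in this assay, the only number among the three.

Compound 4 carries the same change, (pyrrolidin-1-yl in place of piperidin-1-yl on a saturated chain carbon, two bonds along the chain from an amide-type nitrogen), from compound 3. Since the first pair left the step unreadable, only a modest shift is expected: a 1.2-fold higher number from compound 3 to compound 4 (0.08 log units; within the scatter). Compound 4 is therefore estimated at 20000 nM in this assay, with a likely span from 6000 nM to 70000 nM.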

Compound 4, half-maximal inhibitory concentration: 20400 nM
Estimate against measurement, compound 4: 1.0-fold (0.01 log units) below, within the range that was stated.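

In this assay, pyrrolidin-1-yl in place of piperidin-1-yl on the core of compound 3 gives a 1.2-fold higher number from compound 3 to compound 4 (0.09 log units; within the scatter), so on this core the two rings cannot be told apart. On the core of compound 1 the same change cannot be read, and the pair there offers no second size to set against this one, with compound 1 and compound 2 both at a limit of the assay: the limit of > 100000 nM in this assay, at which 2 of the 4 values shown sit.

The readable step therefore rests on one pair, and the unreadable one neither supports nor contradicts it, so it is not shown that the change carries from one core to another.

The compounds shown do not separate the ethyl group on the amide nitrogen from the chlorophenyl, so neither can be tied to the number seen for compound 3. Also open, from the compounds shown here alone, is how morpholin-4-yl, or a chain longer than 2-(pyrrolidin-1-yl)ethyl, would read on the core of compound 3.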